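The source may hold more compounds than are shown below. What is called first, only, known or untested is meant among the compounds shown, and "the series" means these compounds.

Compound 1 `CCc1ccccc1NS(=O)(=O)c1ccc(N2CCNC2=O)cc1` is the starting point. In a functional assay on M21 cells (Homo sapiens) for antiproliferative activity, read by sulforhodamine B assay, with a stated time of 48 h (a lower number here means a stronger inhibitor, a higher number a weaker inhibitor), compound 1 gives 180 nM, the second highest of the three numbers measured. Its nearest neighbour is compound 2 `O=C1NCCN1c1ccc(S(=O)(=O)Nc2ccccc2)cc1`, which in this assay gives 200 nM; the step of a 1.1-fold higher number from compound 1 to compound 2 (0.05 log units; within the scatter) removes the ethyl group entirely. Furthest away is compound 3 `Cc1cccc(NS(=O)(=O)c2ccc(N3CCNC3=O)cc2)c1C`, which in this assay gives 110 nM; the step of a 1.6-fold lower number from compound 1 to compound 3 (0.21 log units; within the scatter) exchanges one substitution pattern on the aromatic ring attached to the sulfonamide nitrogen for another. Between these two, the step of a 1.8-fold lower number from compound 2 to compound 3 (0.26 log units; within the scatter) adds two methyl groups to a bare phenyl.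

Compound 4 `O=C1NCCN1c1ccc(S(=O)(=O)Nc2cccc(Cl)c2)cc1` differs from compound 1 in one place: 3-chlorophenyl in place of 2-ethylphenyl on a sulfonamide nitrogen. All three measured steps touch the same ring on the sulfonamide nitrogen, and every one of them stays within the scatter, whether a group is removed, added or rearranged. The swap of an ethyl for a chlorine, with one fewer heavy atom, is therefore expected to leave the number where it is, with no step beyond the scatter in this assay in either direction. The expected step is a 1.1-fold lower number from compound 1 to compound 4 (0.02 log units; within the scatter). Compound 4 is estimated at 170 nM, within a range of 80 nM to 360 nM.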

Compound 4, half-maximal inhibitory concentration: 25 nM
For compound 4 the middle estimate is 6.8-fold (0.83 log units) above the measured one, and the stated range ends above it.
By their numbers in this assay, from the lowest: compound 4; then compounds 3, 1 and 2 (each within the scatter of the next).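

In this assay, the clearest reading is the step of an 8.0-fold lower number from compound 2 to compound 4 (0.90 log units; beyond the scatter), in which a single chloro takes the place of hydrogen on an aromatic carbon of the otherwise bare phenyl. The other two steps, a 7.2-fold lower number from compound 1 to compound 4 (0.86 log units; beyond the scatter) and a 4.4-fold lower number from compound 3 to compound 4 (0.64 log units; beyond the scatter), point the same way, so the ring on the sulfonamide nitrogen is not as indifferent to change as the first three compounds suggested: among those, ethyl and the two methyl groups left the number within the scatter, whereas the 3-chlorophenyl group moves it beyond the scatter against all three. Nothing available here explains why this one change has so much larger a step than the others.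

The compounds shown leave open whether the lower number belongs to chlorine itself or to the place it occupies on the ring, a question that a bromine or a methyl group in that same place would help to settle. Also open, on these data alone, is how the number would respond to a second chlorine, an amine or a carboxylic acid on this ring.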